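The compounds below may be only part of what the source reports. "The series", "measured", "known", "first", "only" and "open" are said of these compounds alone.

Measured compounds in a functional assay (Hepatocyte) for inhibition, with Rattus norvegicus as the target; on this read-out higher numbers stand for weaker inhibition and lower numbers for stronger inhibition:
- compound 1 `C=C1C[C@@H]1CC(=O)O`: 60000 nM
- compound 2 `C=C1C[C@@H]1CC(N)=O`: 30000 nM
- compound 3 `C=C1[C@H](CCCC)[C@H]1CC(=O)O`: 30000 nM

Compound 1 and compound 2 share a core and differ in one place: amino in place of hydroxy on a carbonyl carbon. In this assay the change gave a 2.0-fold lower number from compound 1 to compound 2 (0.30 log units; within the scatter). Compound 3 carries a different core; the difference between the core of compound 3 and the core of compound 1 is not broken down here. Compound 3 and compound 2 read the same at the digits given, and together they are the lowest of the three numbers, with compound 1 the furthest from them, still within the scatter.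

Compound 4 `C=C1[C@H](CCCC)[C@H]1CC(N)=O` has not yet been measured in this assay. It differs from compound 3 by amino in place of hydroxy on a carbonyl carbon, the same change as between compound 1 and compound 2, and the words describing the surroundings of the place are identical in both cases. The change thus occurs twice among the compounds shown, once with a measurement.

For the measured compounds named here, from compound 3 to compound 4 a step of a 1.5-fold lower number from compound 3 to compound 4 (0.18 log units; within the scatter) is expected in this assay, resting on the single measured instance a 2.0-fold lower number from compound 1 to compound 2 (0.30 log units; within the scatter) and on the value of compound 3, 30000 nM. Compound 4 is estimated at 20000 nM, with an expected range from 8000 nM to 60000 nM.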

Compound 4, half-maximal inhibitory concentration: 60000 nM
Beside the measured number, compound 4's estimate is 3.0-fold (0.48 log units) below it; low and high end bracket the measured number.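

In this assay, amino in place of hydroxy on a carbonyl carbon gives a 2.0-fold higher number from compound 3 to compound 4 (0.30 log units; within the scatter). Set against the earlier step on the core of compound 1, the change does not carry from one core to the other as a fixed step: the same change on two cores in this assay, a 2.0-fold lower number (0.30 log units; within the scatter) from compound 1 to compound 2 and a 2.0-fold higher number (0.30 log units; within the scatter) from compound 3 to compound 4, 4.0-fold (0.60 log units) apart, beyond the scatter of two such steps

Each step taken alone still lies within the scatter and each core offers a single pair, so the series shows no dependable direction for this change on either core, and nothing here tells which difference between the cores goes with the gap.

The compounds shown leave open how other groups on the same carbonyl carbon would read on the two cores, for example methylamino, dimethylamino or a methyl ester in place of hydroxy. They also leave open whether a shorter or longer chain on the core of compound 3 would narrow or widen the gap between the two steps.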